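This account rests on a few compounds, and the source may have more. Where it says the series, first, only, none or still open, it means among the compounds named here.

Measured so far, in a functional assay on THP-1 cells (Homo sapiens) for inhibition, with a stated time of 48 h, tested at 50 uM; on this read-out lower numbers stand for less inhibition of growth and higher numbers for more inhibition of growth at the one concentration tested: compound 1 `C=C[C@@](C)(/C=C/c1ccc(OC(C)=O)cc1)CCC=C(C)C` gives 81%; compound 2 `C=C[C@@](C)(/C=C/c1ccc(OC(=O)CCC)cc1)CCC=C(C)C` gives 54%; compound 3 `C=C[C@@](C)(/C=C/c1ccc(OC(=O)CCCCC)cc1)CCC=C(C)C` gives 54%.

Compound 1 stands highest of the three numbers, with compound 2 and compound 3 both lower by the same amount. Compound 4 `C=C[C@@](C)(/C=C/c1ccc(OC(=O)CCCCCCCCC)cc1)CCC=C(C)C` differs from compound 1 by octyl in place of hydrogen on a saturated chain carbon bound to a carbonyl carbon. Within the data shown here, two measured steps bear on this change, each adding a chain at the same place: a number 27 percentage points lower from compound 1 to compound 2 (beyond the scatter) and a number 27 percentage points lower from compound 1 to compound 3 (beyond the scatter), both modest and beyond the scatter. Going on from there, no change at the digits printed from compound 2 to compound 3 (within the scatter), so a longer chain added nothing further. A drop of similar size is therefore expected for compound 4, a number 31 percentage points lower from compound 1 to compound 4 (beyond the scatter). Compound 4 is estimated at 50%, with a range from 28% to 70%.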

Compound 4, percent growth inhibition at one concentration: 52%
Compound 4: middle estimate off by 2 percentage points, on the low side; the range from low to high includes it.
By their numbers in this assay, from the lowest: compounds 4, 2 and 3 (each within the scatter of the next); then compound 1.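

In this assay, octyl in place of hydrogen on a saturated chain carbon bound to a carbonyl carbon gives a clear loss of growth inhibition (a number 29 percentage points lower from compound 1 to compound 4 (beyond the scatter)), so the drop seen with the shorter chains also holds for this longest chain. Lengthening the chain beyond compound 2 or compound 3 brings no real change (a number 2 percentage points lower from compound 2 to compound 4 (within the scatter); a number 2 percentage points lower from compound 3 to compound 4 (within the scatter)), and both steps lie within the scatter. No evidence is available to explain this flat level.

The compounds shown leave open whether an amine or a carboxylic acid on the chain would bring the number back towards that of compound 1.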